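A few compounds are considered here, and "the series" means these few. Any claim that something is new, unique, unknown or untested is made for them only; others in the source may bear on it.

Compound 2, `CCc1ccc(NC2=CC(=O)c3nc4n(c3C2=O)[C@H]2OC[C@@H](O)[C@H]2OC4)cc1`, gives 960 nM in a functional assay on MCF7 cells (Homo sapiens) for inhibition, read by sulforhodamine B assay (on this read-out lower numbers stand for stronger inhibition and higher numbers for weaker inhibition), the lower of the two numbers reported there. Compound 1, `COc1ccccc1NC1=CC(=O)c2c(nc3n2[C@H]2OC[C@@H](O)[C@H]2OC3)C1=O`, gives 6580 nM in this assay. Compound 3, `O=C1C(NCc2ccccc2)=CC(=O)c2c1nc1n2[C@H]2OC[C@@H](O)[C@H]2OC1`, reaches only the limit of this assay, > 8000 nM. Among the measured compounds shown here, the one measured step, an at least 1.2-fold higher number from compound 1 to compound 3 (0.08 log units; that floor lies within the scatter), is a change at the amine nitrogen and touches the aryl group as a whole rather than a single substituent on it; it is also partly governed by the limit of > 8000 nM in this assay, at which 1 of the 3 values shown sits.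

The move from compound 2 to compound 4, `O=C1C=C(Nc2ccc(I)cc2)C(=O)c2c1nc1n2[C@H]2OC[C@@H](O)[C@H]2OC1`, is iodo in place of ethyl on an aromatic carbon. For the measured compounds named here, no measured step in this set exchanges one substituent for another on the aryl ring, so there is no direct precedent for it; the only recorded step does not bear on this change. The expectation is therefore a step of a 1.3-fold higher number from compound 2 to compound 4 (0.10 log units; within the scatter), not beyond the scatter in either direction. Compound 4 is estimated at 1200 nM in this assay, with a range from 450 nM to 3500 nM.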

Compound 4, half-maximal inhibitory concentration: 2230 nM
The estimate for compound 4 lay 1.9-fold (0.27 log units) below the measured number; the measured number falls inside the stated range.
By their numbers in this assay, from the lowest: compound 2; then compound 4; then compound 1. At a limit, above all of these: compound 3.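

With a 2.3-fold higher number from compound 2 to compound 4 (0.37 log units; beyond the scatter) in this assay, the set gains its first reading of one substituent exchanged for another on the aryl ring, here 4-ethylphenyl to 4-iodophenyl on the amine nitrogen. The step is modest but beyond the scatter, so the aromatic carbon para to a large group is not indifferent to what it carries, although this single exchange is all that speaks for that. Nothing given here accounts for the direction or size of this step.

From the compounds shown here alone, it remains open how other groups at this place would read, among them fluoro, an amine, a carboxylic acid or a chain longer than ethyl such as propyl. Going by these compounds, whether the order of ethyl and iodo would hold on a different amine substituent also remains open.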